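Triazole to imidazole on a series at the assay limit

The source may report more compounds than this note shows. Statements on the series, on what has been measured and on what is new or still open speak of the compounds shown alone.

Measured in a functional assay on SMMC-7721 cells (Homo sapiens) for antiproliferative activity, read by MTT assay, with a stated time of 48 h; on this read-out lower numbers stand for stronger inhibition and higher numbers for weaker inhibition; each entry is a limit, not a number:
- compound 1 `Cn1cc(C2=C(c3nn(CCCn4cncn4)c4ncccc34)C(=O)NC2=O)c2ccccc21`: > 100000 nM
- compound 2 `Cn1cc(C2=C(c3nn(CCn4ccnc4)c4ncccc34)C(=O)N(c3ccccc3)C2=O)c2ccccc21`: > 100000 nM
- compound 3 `Cn1cc(C2=C(c3nn(CCCN4CCCCC4)c4ncccc34)C(=O)N(c3ccc(Cl)cc3)C2=O)c2ccccc21`: > 100000 nM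

Compound 1 has no measured number in this assay, only the limit > 100000 nM. The other two compounds offer no firmer footing, as the set shows (the limit of > 100000 nM in this assay, at which 3 of the 3 values shown sit).

Compound 4 `Cn1cc(C2=C(c3nn(CCCn4ccnc4)c4ncccc34)C(=O)NC2=O)c2ccccc21` is not yet measured. It carries 1H-imidazol-1-yl in place of 1H-1,2,4-triazol-1-yl on a saturated chain carbon, three bonds along the chain from an aromatic nitrogen.

Among the measured compounds shown here, no measured pair isolates this change, so its size cannot be read from the data. Compound 2 also carries 1H-imidazol-1-yl, on a 2-(1H-imidazol-1-yl)ethyl chain, and its result is the limit > 100000 nM. A small shift toward stronger inhibition is expected at best, and another limit would be no surprise. The expected size is an at least 1.4-fold lower number from compound 1 to compound 4 (0.15 log units; that floor lies within the scatter). For compound 4 the estimate is 70000 nM, with an expected range from 15000 nM to 150000 nM.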

Compound 4, half-maximal inhibitory concentration: > 100000 nM
Compound 4 gave a limit, no number (the forecaster's own chance of this, stated with the estimate: 55%); middle value at least 1.4-fold (0.15 log units) from the limit.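

Compound 1 and compound 4 each give only a limit, so no step can be read for 1H-imidazol-1-yl in place of 1H-1,2,4-triazol-1-yl: the limit of > 100000 nM in this assay, at which 4 of the 4 values shown sit.

The compounds shown leave open the size of this change and whether any compound in the series gives a measured number in this assay.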